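Sulfonyl pyridopyrimidinone series: methyl for fluoro on the aryl sulfone

The compounds below may be only part of what the source reports. "The series", "measured", "known", "first", "only" and "open" are said of these compounds alone.

Measured so far in a functional assay on DU-145 cells (Homo sapiens) for inhibition, read by trypan blue exclusion, with a stated time of 72 h; a lower number here means a stronger inhibitor, a higher number a weaker inhibitor:
compound 1 `Cn1c(=O)c(S(=O)(=O)c2ccc(F)cc2)cc2cnc(Nc3cccc4[nH]ccc34)nc21`, 750 nM
compound 2 `Cc1ccc(S(=O)(=O)c2cc3cnc(Nc4ccc5cc[nH]c5c4)nc3n(C)c2=O)cc1`, 15000 nM
compound 3 `Cn1c(=O)c(S(=O)(=O)c2ccc(F)cc2)cc2cnc(Nc3cnc4[nH]ccc4c3)nc21`, 500 nM

Compound 3 gives the lowest of the three numbers; compound 1 is nearest, the gap being within the scatter, and compound 2 is furthest, beyond the scatter. Going by the values given here, the only single-point step measured is a 1.5-fold lower number from compound 1 to compound 3 (0.18 log units; within the scatter), and it concerns the group on the aromatic nitrogen, not the aryl sulfone.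

Compound 4 `Cc1ccc(S(=O)(=O)c2cc3cnc(Nc4cnc5[nH]ccc5c4)nc3n(C)c2=O)cc1` differs from compound 3 by methyl in place of fluoro on an aromatic carbon.

Among the compounds with values here, no measured pair isolates this change. Compound 2 carries the same 4-methylphenyl sulfonyl as compound 4 and gives a high number in this assay, but it also differs from compound 3 on the aromatic nitrogen, so its value cannot be assigned to the methyl alone. The expectation for compound 4 is therefore a weaker inhibitor than compound 3, with a step of a 6.0-fold higher number from compound 3 to compound 4 (0.78 log units; beyond the scatter), and a wide range. Compound 4 is estimated at 3000 nM, between 900 nM and 10000 nM.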

Compound 4, half-maximal inhibitory concentration: 25000 nM
Estimate against measurement, compound 4: 8.3-fold (0.92 log units) below; the whole stated range lies below it.
By their numbers in this assay, from the lowest: compounds 3 and 1 (each within the scatter of the next); then compounds 2 and 4 (each within the scatter of the next).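

In this assay, the change from 4-fluorophenyl to 4-methylphenyl on the sulfonyl now has a direct reading, a 50-fold higher number from compound 3 to compound 4 (1.70 log units; beyond the scatter), so this position is far from indifferent to methyl in place of fluoro, at least with the group on the aromatic nitrogen that these two compounds share. With the 4-methylphenyl sulfonyl held fixed, the change on the aromatic nitrogen gives a 1.7-fold higher number from compound 2 to compound 4 (0.22 log units; within the scatter), which lies within the scatter as does a 1.5-fold lower number from compound 1 to compound 3 (0.18 log units; within the scatter), so the weak numbers of both methyl compounds go with the methyl rather than with that group. Nothing at hand explains the size of the step.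

Going by these compounds, how hydrogen, chloro, methoxy or an amine would read at this place remains open. Also open, on these data alone, is whether a longer chain such as ethyl would track the methyl.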